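Indole swaps on a diphenylmethylpiperazine butyl chain

The source may report more compounds than this note shows. Statements on the series, on what has been measured and on what is new or still open speak of the compounds shown alone.

Three compounds share a diphenylmethylpiperazine linked through a four-carbon chain to a bicyclic aromatic group. Compound 1 `Cc1nc2ccccc2n1CCCCN1CCN(C(c2ccccc2)c2ccccc2)CC1` carries a 2-methyl-1H-benzimidazol-1-yl group and in an assay on RPMI-8226 cells for antagonist activity at P2X purinoceptor 7 (Homo sapiens), read by calcium flux (on this read-out higher numbers stand for weaker inhibition and lower numbers for stronger inhibition), compound 1 gives 850 nM. Compound 2 `Cc1ccc2ccn(CCCCN3CCN(C(c4ccccc4)c4ccccc4)CC3)c2c1` gives 6500 nM, and compound 3 `N#Cc1ccc2c(ccn2CCCCN2CCN(C(c3ccccc3)c3ccccc3)CC2)c1` gives 3800 nM. Compound 3 thus stands second highest of the three numbers; one step, a 1.7-fold lower number from compound 2 to compound 3 (0.23 log units; within the scatter), lies within the scatter, while the other, a 4.5-fold higher number from compound 1 to compound 3 (0.65 log units; beyond the scatter), lies beyond it. The two indoles sit close together, both well above the benzimidazole of compound 1, as a 7.6-fold higher number from compound 1 to compound 2 (0.88 log units; beyond the scatter) also shows.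

Compound 4 `Fc1ccc2ccn(CCCCN3CCN(C(c4ccccc4)c4ccccc4)CC3)c2c1` is the next member: 6-fluoro-1H-indol-1-yl in place of 5-cyano-1H-indol-1-yl on a saturated chain carbon, four bonds along the chain from an amine nitrogen in a ring. Going by the values given here, no measured step exchanges one substituent on an indole for another; the only step between two indoles, a 1.7-fold lower number from compound 2 to compound 3 (0.23 log units; within the scatter), lies within the scatter. On that basis the swap from nitrile to fluorine on the indole is expected to move the number little, and the step of a 1.2-fold higher number from compound 3 to compound 4 (0.07 log units; within the scatter) is the estimate given here, with compound 3 as the anchor. Compound 4 is therefore expected to give about 4500 nM, within a range of 1500 nM to 13000 nM.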

Compound 4, half-maximal inhibitory concentration: 110 nM
Compound 4: middle estimate off by 41-fold (1.61 log units), on the high side; measured number below the stated range.
By their numbers in this assay, from the lowest: compound 4; then compound 1; then compounds 3 and 2 (each within the scatter of the next).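

In this assay, the substituent on the indole proves to matter far more than the within-scatter step from compound 2 to compound 3 had suggested: fluoro in place of methyl on an aromatic carbon gives a 59-fold lower number from compound 2 to compound 4 (1.77 log units; beyond the scatter) and a large drop, while 6-fluoro-1H-indol-1-yl in place of 5-cyano-1H-indol-1-yl gives a 35-fold lower number from compound 3 to compound 4 (1.54 log units; beyond the scatter) and a drop of similar scale. The indole is therefore not bound to sit above the benzimidazole, since 6-fluoro-1H-indol-1-yl in place of 2-methyl-1H-benzimidazol-1-yl gives a 7.7-fold lower number from compound 1 to compound 4 (0.89 log units; beyond the scatter) and reverses the order seen for compound 2 and compound 3, which both stand above compound 1. No evidence at hand explains these steps.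

The compounds shown leave open whether the low number is particular to fluoro or would also appear with chloro, methoxy or a hydroxyl group on the indole. They also leave open whether it would survive a pentyl chain in place of the four-carbon chain, or a fluoro group placed on the benzimidazole of compound 1.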